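The compounds below may be only part of what the source reports. "The series", "measured", "known", "first", "only" and "open" are said of these compounds alone.

Measured in a functional assay on DU-145 cells (Homo sapiens) for cytotoxicity, read by trypan blue exclusion, with a stated time of 96 h; on this read-out higher numbers stand for weaker inhibition and lower numbers for stronger inhibition:
- compound 1 `COc1cc(OC)c(/C=C/S(=O)(=O)Cc2ccc(F)c(N)c2)c(OC)c1`: 2500 nM
- compound 2 `COc1ccc(CS(=O)(=O)/C=C/c2cc(F)c(F)cc2F)cc1N`: 5000 nM
- compound 3 `COc1ccc(/C=C/S(=O)(=O)Cc2ccc(OC)c([N+](=O)[O-])c2)cc1`: 25000 nM

In this assay, compound 1 at 2500 nM and compound 2 at 5000 nM lie within the scatter of each other. Compound 3 at 25000 nM stands beyond the scatter from compound 1, with the higher number.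

Compound 4 `COc1cc(OC)c(/C=C/S(=O)(=O)Cc2cc(N)ccc2OC)c(OC)c1` has not yet been measured. It differs from compound 1 as follows: 5-amino-2-methoxyphenyl in place of 3-amino-4-fluorophenyl on a saturated chain carbon bound to a sulfonyl sulfur. Here 5-amino-2-methoxyphenyl takes the place of 3-amino-4-fluorophenyl on a saturated chain carbon bound to a sulfonyl sulfur.

Going by the values given here, no measured pair isolates this change, so the data give no direct guide, and in this assay no step beyond the scatter is expected. The expected change is a 1.7-fold lower number from compound 1 to compound 4 (0.22 log units; within the scatter). The estimate for compound 4 is 1500 nM, with an expected range from 150 nM to 10000 nM.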

Compound 4, half-maximal inhibitory concentration: 7500 nM
Compound 4: the middle estimate sits 5.0-fold (0.70 log units) below what was measured, within the range that was stated.
By their numbers in this assay, from the lowest: compounds 1, 2 and 4 (each within the scatter of the next, the first and the last beyond it); then compound 3.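

In this assay, going by these compounds alone, the entry of 5-amino-2-methoxyphenyl in place of 3-amino-4-fluorophenyl on a saturated chain carbon bound to a sulfonyl sulfur gives a 3.0-fold higher number from compound 1 to compound 4 (0.48 log units; beyond the scatter) and is the first step read at this place with the rest of the compound held fixed. The place therefore responds to a change of its group, modestly and towards weaker inhibition. Nothing at hand accounts for this step.

The compounds shown do not separate the part played by the fluorine from that of the methoxy group, nor the part played by where the amine sits. They also leave open how a hydroxyl group or a carboxylic acid in place of that amine would read.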